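From 4-methoxyphenyl to 3-hydroxyphenyl on the shared core

This account rests on a few compounds, and the source may have more. Where it says the series, first, only, none or still open, it means among the compounds named here.

Measured in a functional assay on A549 cells (Homo sapiens) for antiproliferative activity, read by MTT assay, with a stated time of 48 h; on this read-out higher numbers stand for weaker inhibition of growth and lower numbers for stronger inhibition of growth:
compound 1 `CCOC(=O)N1N=C(c2ccccc2)CC1c1cc(OC)c(OC)c(OC)c1`: 6680 nM
compound 2 `CCOC(=O)N1N=C(c2ccc(OC)cc2)CC1c1cc(OC)c(OC)c(OC)c1`: 4690 nM
compound 3 `CCCOC(=O)N1N=C(c2ccc(OC)cc2)CC1c1cc(OC)c(OC)c(OC)c1`: > 10000 nM (a limit)

In this assay, compound 2 gives 4690 nM, which lies within the scatter of compound 1 with 6680 nM. Compound 3 gives only a limit, > 10000 nM.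

Compound 4 `CCOC(=O)N1N=C(c2cccc(O)c2)CC1c1cc(OC)c(OC)c(OC)c1` differs from compound 2 in one place: 3-hydroxyphenyl in place of 4-methoxyphenyl on a carbon with a double bond to nitrogen. The most relevant measurement is the step of a 1.4-fold lower number from compound 1 to compound 2 (0.15 log units; within the scatter), which changes the same phenyl group and stays within the scatter. The step of an at least 2.1-fold higher number from compound 2 to compound 3 (0.32 log units; beyond the scatter) is larger, but it lies on the saturated chain, elsewhere in the molecule, and bears only indirectly on this change. No hydroxy compound has been measured yet, so the direction remains open, and no step beyond the scatter is expected, given the small step to compound 2 shown by a 1.4-fold lower number from compound 1 to compound 2 (0.15 log units; within the scatter). The estimated step is a 1.2-fold higher number from compound 2 to compound 4 (0.07 log units; within the scatter). For compound 4 the expected value is 5500 nM, with an estimated range of 1800 nM to 14000 nM.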

Compound 4, concentration for 50% growth inhibition: 5120 nM
The estimate for compound 4 lay 1.1-fold (0.03 log units) above the measured number; low and high end bracket the measured number.
By their numbers in this assay, from the lowest: compounds 2, 4 and 1 (each within the scatter of the next). At a limit, above all of these: compound 3.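

In this assay the exchange of 4-methoxyphenyl for 3-hydroxyphenyl gives a 1.1-fold higher number from compound 2 to compound 4 (0.04 log units; within the scatter) and so shows that a hydrogen-bond donor on this phenyl group, where compound 2 has none, brings no step beyond the scatter. Compared with the unsubstituted phenyl group, the result is the same, with a 1.3-fold lower number from compound 1 to compound 4 (0.12 log units; within the scatter) and thus the three compounds with these groups cannot be told apart in this assay. The data shown give no measured reason for this result.

As far as these compounds go, whether this position stays as undemanding with an amine or a carboxylic acid on the phenyl group remains open. From the compounds shown here alone, for compound 3 the value > 10000 nM is a limit, and whether 3-hydroxyphenyl would read differently alongside its longer chain also remains open.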